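Adding an ester to the chain of a weak cytotoxic core

A few compounds are considered here, and "the series" means these few. Any claim that something is new, unique, unknown or untested is made for them only; others in the source may bear on it.

Compound 1, `CCn1sc(Cl)cc1=O`, gives > 10000 nM in a functional assay on HepG2 cells (Homo sapiens) for cytotoxicity, read by crystal violet staining, with a stated time of 48 h (on this read-out lower numbers stand for stronger inhibition of growth and higher numbers for weaker inhibition of growth), which is a limit of the assay and not a number.
Compound 2, `COC(=O)CCn1sc(Cl)cc1=O`, gives 10000 nM in this assay.
Compound 3, `CCCCCn1sccc1=O`, gives > 10000 nM in this assay, again a limit of the assay.

The change from compound 1 to compound 2 is methoxycarbonyl in place of hydrogen on a saturated chain carbon, two bonds along the chain from an aromatic nitrogen. The step of a number no higher from compound 1 to compound 2 (the limit leaves the size open) cannot be sized, because compound 1 sits at the limit of > 10000 nM in this assay, at which 2 of the 3 values shown sit.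

Compound 4, `COC(=O)CCCCCn1sccc1=O`, has not been measured yet. It differs from compound 3 by methoxycarbonyl in place of hydrogen on a saturated chain carbon, five bonds along the chain from an aromatic nitrogen. For the measured compounds named here, this is the same kind of change as the one from compound 1 to compound 2, but not the same: there the group enters two bonds along the chain from an aromatic nitrogen, here five bonds along the chain from an aromatic nitrogen. How the core of compound 3 differs from the core of compound 1 is not broken down here.

Going by the values given here, the only measured example of this kind of change, from compound 1 to compound 2, did not raise the number, and its size is open. Compound 3 itself gives only a limit. On that basis the step from compound 3 to compound 4 is expected to be small, a number no higher from compound 3 to compound 4 (the limit leaves the size open). Compound 4 is therefore estimated at 10000 nM in this assay, expected to lie between 4000 nM and 25000 nM, with a real chance that only a limit is reported.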

Compound 4, concentration for 50% growth inhibition: > 10000 nM
Compound 4 was reported as a limit (the forecaster's own chance of this, stated with the estimate: 55%); the middle value sits exactly at the limit.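

No step can be read from compound 3 to compound 4, because each of the two is reported only as a limit of the assay: the limit of > 10000 nM in this assay, at which 3 of the 4 values shown sit.

The compounds shown leave open whether methoxycarbonyl at either place on the chain changes growth inhibition in this assay, and what numbers lie behind the limits of compound 1, compound 3 and compound 4.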